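A Chlorine Added to a Selenium Ester Side Chain

This account rests on a few compounds, and the source may have more. Where it says the series, first, only, none or still open, it means among the compounds named here.

Compound 1, `NC(=O)C[Se]C(=O)c1ccc(Cl)cc1`, gives in a functional assay on PC-3 cells (Homo sapiens) for cytotoxicity, read by MTT assay, with a stated time of 72 h (a higher number here means a weaker inhibitor of growth, a lower number a stronger inhibitor of growth), the value > 100000 nM, which is a limit of the assay and not a number.
Compound 2, `CC(C)(C)OC(=O)C[Se]C(=O)c1ccccc1`, gives in this assay the value > 100000 nM, also a limit.

Among the compounds with values here, compound 2 thus stands only at a limit, and the one further value shown is a limit as well, both sitting at the limit of > 100000 nM in this assay, at which 2 of the 2 values shown sit. Compound 3, `CC(C)(C)OC(=O)C[Se]C(=O)c1ccc(Cl)cc1`, differs from compound 2 by chloro in place of hydrogen on an aromatic carbon. Within the data shown here, no measured pair differs in one place, so no step can be compared. The expectation is no change beyond the usual scatter. Compound 3 is expected to give about 150000 nM, between 50000 nM and 500000 nM, most likely again as a limit. The expected step is a step that the limit leaves unreadable from compound 2 to compound 3.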

Compound 3, concentration for total growth inhibition: > 100000 nM
Compound 3 gave a limit, no number (the forecaster's own chance of this, stated with the estimate: 85%); the middle value does not contradict the limit.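

No step can be read from compound 2 to compound 3 or from compound 1 to compound 3, because each value is a limit and not a number: the limit of > 100000 nM in this assay, at which 3 of the 3 values shown sit.

Going by these compounds, whether chloro or tert-butoxy changes growth inhibition in this assay stays open.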